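Two fluorines in place of trifluoromethyl on the ring nitrogen

The source may hold more compounds than are shown below. What is called first, only, known or untested is meant among the compounds shown, and "the series" means these compounds.

compound 1 `Nc1scc(CN2CCN(c3cccc(C(F)(F)F)c3)CC2)c1C(=O)c1ccc(Cl)cc1` — -8.2%
compound 2 `Nc1scc(CN2CCN(c3ccc(OC(F)(F)F)cc3)CC2)c1C(=O)c1ccc(Cl)cc1` — 0%
compound 3 `Nc1scc(CN2CCN(c3ccc(C(F)(F)F)cc3)CC2)c1C(=O)c1cccc(C(F)(F)F)c1` — -12%

In a functional assay on CHO cells with adenosine receptor A1 (Homo sapiens) as the target, read by cAMP accumulation and immunoassay, with a stated time of 6 min, tested at 0.01 uM (a higher number here means a weaker effect of the compound at the concentration tested, a lower number a stronger effect), compound 1 gives -8.2%, the second highest of the three numbers. Compound 3 gives -12% and compound 2 gives 0%, and both of these lie within the scatter of compound 1, so the three measured compounds cannot be ordered.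

Compound 4 `Nc1scc(CN2CCN(c3cc(F)cc(F)c3)CC2)c1C(=O)c1ccc(Cl)cc1` differs from compound 1 in one place:

3,5-difluorophenyl in place of 3-(trifluoromethyl)phenyl on an amine nitrogen in a ring

Among the measured compounds shown here, the only measured step that touches the same place is a number 8.2 percentage points higher from compound 1 to compound 2 (within the scatter), which stays within the scatter. Compound 4 is therefore expected to show no step beyond the scatter, that is a number 3.2 percentage points higher from compound 1 to compound 4 (within the scatter). For compound 4 the estimate in this assay is -5%, with a range from -20% to 10%.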

Compound 4, a percentage reported as activity, at one concentration (the size of the read-out at that concentration, not a potency): -13%
Compound 4: the middle estimate sits 8 percentage points above what was measured, within the range that was stated.
By their numbers in this assay, from the lowest: compounds 4, 3, 1 and 2 (each within the scatter of the next, the first and the last beyond it).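

In this assay, 3,5-difluorophenyl in place of 3-(trifluoromethyl)phenyl gives a number 4.8 percentage points lower from compound 1 to compound 4 (within the scatter) and so leaves the read-out unchanged at this position on the ring nitrogen. Set against 4-(trifluoromethoxy)phenyl, the same group gives a number 13 percentage points lower from compound 2 to compound 4 (beyond the scatter) and this is the first step in the series beyond the scatter, though only a modest one. Nothing available explains this step. Going by these compounds, it remains open whether an unsubstituted phenyl, or a phenyl carrying an amine or a carboxylic acid, would move the read-out further at this position.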